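The source may hold more compounds than are shown below. What is called first, only, known or untested is meant among the compounds shown, and "the series" means these compounds.

Compound 3 `O=C(O)c1c(O)c(C2(c3ccsc3)CC2)nc2c(C(F)(F)F)cccc12` gives 7% in an assay on isolated protein for inhibition of P-selectin glycoprotein ligand 1 (Homo sapiens), read by surface plasmon resonance, tested at 250 uM (a higher number here means more inhibition at the concentration tested (going by the name of the read-out), a lower number less inhibition), the smallest of the three numbers, though the gap to compound 2 `O=C(O)c1c(O)c(C2(c3cccs3)CC2)nc2c(C(F)(F)F)cccc12`, which gives 15%, is only a number 8 percentage points lower from compound 2 to compound 3 (within the scatter). Compound 1 `CC(Cc1nc2c(C(F)(F)F)cccc2c(C(=O)O)c1O)c1ccccc1` gives 46%, and the drops a number 31 percentage points lower from compound 1 to compound 2 (beyond the scatter) and a number 39 percentage points lower from compound 1 to compound 3 (beyond the scatter) show how much the 2-phenylpropyl group carried. Compound 4 `O=C(O)c1c(O)c(C2Cc3ccccc3C2)nc2c(C(F)(F)F)cccc12` changes this position again: 2,3-dihydro-1H-inden-2-yl in place of 1-(thiophen-3-yl)cyclopropyl on an aromatic carbon. For the measured compounds named here, no measured step covers this exact exchange; the two large steps from compound 1 suggest the group here matters strongly, while the thiophene swap was within the scatter. For compound 4 a moderate rise is expected, a number 15 percentage points higher from compound 3 to compound 4 (beyond the scatter), since a carbon-only bicyclic group moves closer to compound 1 than either thiophene. Compound 4 is estimated at 22%, within 2% to 45%.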

Compound 4, a percentage reported as inhibition, at one concentration (the size of the read-out at that concentration, not a potency): 35%
For compound 4 the middle estimate is 13 percentage points below the measured one; measured number inside the range.
By their numbers in this assay, from the lowest: compounds 3 and 2 (each within the scatter of the next); then compound 4; then compound 1.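

In this assay the 2,3-dihydro-1H-inden-2-yl group gives back much of what the thiophene-bearing groups lost, with a number 28 percentage points higher from compound 3 to compound 4 (beyond the scatter) and a number 20 percentage points higher from compound 2 to compound 4 (beyond the scatter). The 2-phenylpropyl group still stays ahead of it, with a number 11 percentage points lower from compound 1 to compound 4 (beyond the scatter), so a carbon-only fused group is accepted at this position without matching the open chain. No evidence is available to explain these differences. Because the ring size, the aromatic ring and the attachment all change together, the step does not show which of them matters. On these data alone, a 1-phenylcyclopropyl group would separate the aromatic ring from the cyclopropyl, and how an amine on the indane group would read also remains open.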